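This account rests on a few compounds, and the source may have more. Where it says the series, first, only, none or still open, it means among the compounds named here.

Measured in a functional assay on A549 cells (Homo sapiens) for cytotoxicity, read by MTT assay; a lower number here means a stronger inhibitor, a higher number a weaker inhibitor:
Compound 1 `COc1ccc(OC)c(C(=O)/C=C/c2ccco2)c1`: 27900 nM
Compound 2 `COc1ccc(OC)c(C(=O)/C=C/c2ccc(C)o2)c1`: 51500 nM
Compound 3 `COc1ccc(OC)c(C(=O)/C=C/c2ccc(C)s2)c1`: 4500 nM

Compound 3 has the lowest number of the three in this assay, and its gaps to the other two lie beyond the scatter. Compound 4 `COc1ccc(OC)c(C(=O)/C=C/c2sccc2C)c1` has the same atoms as compound 3, joined differently: 3-methylthiophen-2-yl in place of 5-methylthiophen-2-yl on a double-bonded chain carbon bound to a double-bonded chain carbon. It carries 3-methylthiophen-2-yl in place of 5-methylthiophen-2-yl on a double-bonded chain carbon bound to a double-bonded chain carbon.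

For the measured compounds named here, no measured step shifts a methyl from one ring carbon to another, so the evidence is indirect. Adding a methyl to the furan ring gave a 1.8-fold higher number from compound 1 to compound 2 (0.27 log units; within the scatter), a step too small to read. Exchanging the ring gave much larger steps: an 11-fold lower number from compound 2 to compound 3 (1.06 log units; beyond the scatter), and a 6.2-fold lower number from compound 1 to compound 3 (0.79 log units; beyond the scatter). Compound 4 keeps the thiophene ring that marks compound 3, so only a small step is expected, with no large loss. Compound 3, at 4500 nM, sits at the low end of the series, so any drift is expected toward a higher number. The expected change is a 1.6-fold higher number from compound 3 to compound 4 (0.19 log units; within the scatter). For compound 4 the estimated value is 7000 nM, with an expected range from 2500 nM to 20000 nM.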

Compound 4, half-maximal inhibitory concentration: 22200 nM
Estimate against measurement, compound 4: 3.2-fold (0.50 log units) below; measured number above the stated range.
By their numbers in this assay, from the lowest: compound 3; then compounds 4, 1 and 2 (each within the scatter of the next, the first and the last beyond it).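

In this assay, for the compounds shown here, the shift of the methyl from 5-methylthiophen-2-yl to 3-methylthiophen-2-yl gives a 4.9-fold higher number from compound 3 to compound 4 (0.69 log units; beyond the scatter) and is the first step with the thiophene ring kept on both sides, so where the methyl sits on that ring matters as well as which ring is present. The thiophene ring alone therefore does not secure the low number of compound 3: 3-methylthiophen-2-yl in place of 5-methylfuran-2-yl gives a 2.3-fold lower number from compound 2 to compound 4 (0.37 log units; beyond the scatter) and still leaves a clear gain, whereas 3-methylthiophen-2-yl in place of furan-2-yl gives a 1.3-fold lower number from compound 1 to compound 4 (0.10 log units; within the scatter) and so shows no readable change. Nothing available here explains why the two methylthiophene isomers part in this way.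

The compounds shown leave open how plain thiophen-2-yl, with no methyl, or 4-methylthiophen-2-yl would fall relative to compound 3 and compound 4. They also leave open whether 3-methylfuran-2-yl would follow the thiophene pair, and whether a larger group such as ethyl or a halogen such as chlorine in the place of the methyl would keep the number of compound 3.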